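The source may report more compounds than this note shows. Statements on the series, on what has been measured and on what is new or still open speak of the compounds shown alone.

Measured compounds:
Compound 1, `C#CCOC(=O)CC1C(C(=O)OCC#C)=C(N)Oc2ccc(-c3cc(OC)cc(OC)c3)cc21`, 1500 nM
Compound 2, `C#CCOC(=O)CC1C(C(=O)OCC)=C(N)Oc2ccc(-c3cc(OC)cc(OC)c3)cc21`, 4700 nM
Compound 3, `CCOC(=O)CC1C(C(=O)OCC)=C(N)Oc2ccc(-c3cccc(N)c3)cc21`, 20200 nM

In a functional assay on HL-60 cells (Homo sapiens) for cytotoxicity, read by CellTiter-Blue, with a stated time of 48 h (on this read-out higher numbers stand for weaker inhibition and lower numbers for stronger inhibition), compound 1 gives the lowest of the three numbers. Its nearest neighbour is compound 2, and that step, a 3.1-fold higher number from compound 1 to compound 2 (0.50 log units; beyond the scatter), involves methyl in place of ethynyl on a saturated chain carbon bound to an oxygen next to a carbonyl group. Going by the values given here, compound 3 lies furthest away; it differs from compound 2 in two places, both at the ester and at the aryl group, so no single step can be read from the pair, and what the two values show is only that compound 3 is the weaker of the two.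

Compound 4, `C#CCOC(=O)CC1C(C(=O)OCC#C)=C(N)Oc2ccc(-c3ccc(N(C)C)cc3)cc21`, is not yet measured. It keeps the two propargyl esters of compound 1 and changes the aryl group: 4-(dimethylamino)phenyl in place of 3,5-dimethoxyphenyl on an aromatic carbon. Among the compounds with values here, no measured step touches the aryl group alone. Within the data shown here, the only aryl change in the set is buried in the pair of compound 2 and compound 3, which moves in the direction of weaker inhibition but is confounded by the ester change. Compound 4 is therefore expected to sit somewhat above compound 1, by an estimated 2.0-fold higher number from compound 1 to compound 4 (0.30 log units; within the scatter), with wide uncertainty. The estimate for compound 4 is 3000 nM, in a range from 800 nM to 12000 nM.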

Compound 4, half-maximal inhibitory concentration: 2560 nM
The estimate for compound 4 lay 1.2-fold (0.07 log units) above the measured number; low and high end bracket the measured number.
By their numbers in this assay, from the lowest: compounds 1, 4 and 2 (each within the scatter of the next, the first and the last beyond it); then compound 3.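

Going by these compounds alone, with the two propargyl esters held fixed, the aryl group is changed alone here for the first time, and in this assay 4-(dimethylamino)phenyl in place of 3,5-dimethoxyphenyl gives a 1.7-fold higher number from compound 1 to compound 4 (0.23 log units; within the scatter). On this core, then, the two aryl groups cannot be told apart by this read-out, so the dimethoxy pattern of compound 1 is not required at this aromatic carbon for a number in this range. That is a result the earlier compounds could not give, as their only other aryl change comes together with an ester change and cannot be read as a step, and nothing shown here offers a reason for the result.

The compounds shown leave open whether an unsubstituted phenyl, a pyridine ring or a phenyl bearing a carboxylic acid would stay in the same range on the core of compound 1. They also leave open whether 3-(dimethylamino)phenyl would match 4-(dimethylamino)phenyl, and whether the latter group behaves alike when an ethyl ester replaces a propargyl ester.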